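The source may hold more compounds than are shown below. What is called first, only, known or untested is meant among the compounds shown, and "the series" means these compounds.

In an ADME assay on a cell-free system (plasma, Rattus norvegicus) for metabolic stability, read by LC-MS, with a stated time of 1 h, at 37 degrees C, tested at 100 uM (on this read-out lower numbers stand for a less stable compound and higher numbers for a more stable compound), compound 1 (`Cn1sc2cc(OCc3cccc(-c4ccc(Cl)c(C(=O)O)c4)c3)ccc2c1=O`) gives 100%, and compound 3 (`Cc1ccc(C(=O)O)cc1-c1cccc(COc2ccc3c(=O)n(C4CCCC4)sc3c2)c1`) gives 100%. Compound 2 (`O=C1c2ccc(OCc3cccc(-c4ccc(C(F)(F)F)cc4F)c3)cc2CN1C1CCCC1`) offers no number to set beside these: its result reads "not determined" (no result reported), so it provides no starting value on this scale. Compound 4 (`O=C(O)c1ccc(-c2cccc(COc3ccc4c(c3)CN(C3CCCC3)C4=O)c2)c(Cl)c1`) has yet to be measured. The structural change leading to it is 4-carboxy-2-chlorophenyl in place of 2-fluoro-4-(trifluoromethyl)phenyl on an aromatic carbon, with 4-carboxy-2-chlorophenyl in place of 2-fluoro-4-(trifluoromethyl)phenyl on an aromatic carbon. Within the data shown here, no measured step shows what such a change does in this assay, and the size of the step from compound 2 cannot be stated without a value for compound 2. The nearest guide is the pair of compounds that also carry a carboxy-substituted phenyl group, though on a different core: compound 1 at 100% and compound 3 at 100%. On that basis, little or no loss beyond the usual scatter is expected relative to those two values. For compound 4, the estimated value is 96%, with an expected range of 82% to 104%.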

Compound 4, percent of the compound remaining: 100%
Estimate against measurement, compound 4: 4 percentage points below; the range from low to high includes it.
By their numbers in this assay, from the lowest: compounds 1, 3 and 4 (each within the scatter of the next).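

In this assay compound 4 gives 100% but compound 2 has no value, so no step between them can be read, and no evidence on hand explains the result. Left open is how a compound without a carboxy group would fare on this read-out.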